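A few compounds are considered here, and "the series" means these few. Any claim that something is new, unique, unknown or untested is made for them only; others in the source may bear on it.

Measured so far:
- compound 1 `Cc1ccc(C(=O)Nc2ccc(C(F)(F)F)cc2)cc1C#Cc1cc(-c2cnn(C)c2)cnc1N`: 14 nM
- compound 2 `Cc1ccc(C(=O)Nc2ccc(Cl)cc2Cl)cc1C#Cc1cc(-c2cnn(C)c2)cnc1N`: "not determined" (no result reported)

In an ADME assay on RBL-2H3 cells (Rattus norvegicus) for cytotoxicity, read by CCK-8 assay, with a stated time of 24 h (on this read-out lower numbers stand for higher toxicity in this test and higher numbers for lower toxicity in this test), compound 1 gives 14 nM. For compound 2 this assay gives no single number, so compound 2 stands nowhere on the scale shown. Compound 3 `Cc1ccc(C(=O)Nc2ccc(OC(F)(F)F)cc2)cc1C#Cc1cc(-c2cnn(C)c2)cnc1N` differs from compound 2 by 4-(trifluoromethoxy)phenyl in place of 2,4-dichlorophenyl on an amide-type nitrogen. Among the compounds with values here, no measured step covers this change, so neither its size nor its direction in this assay can be read from the series; compound 1 is the only anchor, and compound 3 sits closer to it in the amide part. Compound 3 is therefore expected near 20 nM, within 5 nM to 80 nM.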

Compound 3, half-maximal cytotoxic concentration: 41 nM
Compound 3: middle estimate off by 2.1-fold (0.31 log units), on the low side; the measured number falls inside the stated range.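

In this assay, trifluoromethoxy in place of trifluoromethyl on an aromatic carbon gives a 2.9-fold higher number from compound 1 to compound 3 (0.47 log units; beyond the scatter) and so shows that this place in the amide part responds to a one-place change, which compound 1 alone could not show. Steps involving compound 2 cannot be read, as it has no single number. No evidence bears on the cause of this step.

Still open, going by these compounds, is how this read-out responds to other groups on that aromatic carbon, such as an amine or a carboxylic acid.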